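This account rests on a few compounds, and the source may have more. Where it says the series, first, only, none or still open, it means among the compounds named here.

Among the compounds with values here, in a functional assay on CaEs17 cells (Homo sapiens) for cytotoxicity, read by MTT assay, with a stated time of 72 h (on this read-out lower numbers stand for stronger inhibition and higher numbers for weaker inhibition), compound 1 (`C=C1C(=O)[C@@]23C(=O)OC[C@]4([C@@H](OC(C)=O)CCC(C)(C)[C@H]4C=O)[C@@H]2CC[C@@H]1[C@H]3O`) gives 72600 nM as the highest number of the three measured so far, and compound 2 (`C=C1C(=O)[C@@]23C(=O)OC[C@]4(C(=O)CCC(C)(C)[C@H]4C=O)[C@@H]2CC[C@@H]1[C@H]3OC(=O)CC`) gives 1400 nM as the lowest. Compound 3 (`C=C1C(=O)[C@@]23C(=O)OC[C@]4(C(=O)CCC(C)(C)[C@H]4C=O)[C@@H]2CC[C@@H]1[C@H]3OC(=O)c1ccc(OC)cc1`) stands second highest at 2980 nM on this read-out, a modest distance above compound 2 and far under compound 1.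

The next analogue is compound 4 (`C=C1C(=O)[C@@]23C(=O)OC[C@]4(C(=O)CCC(C)(C)[C@H]4C=O)[C@@H]2CC[C@@H]1[C@H]3OC(=O)c1ccc(Cl)cc1`), which differs from compound 3 in one place. The change is chloro in place of methoxy on an aromatic carbon and reads in short as chloro in place of methoxy on an aromatic carbon.

Within the data shown here, only one measured step bears on it: a 2.1-fold higher number from compound 2 to compound 3 (0.33 log units; beyond the scatter) when 4-methoxyphenyl stands in place of ethyl on a carbonyl carbon. That step exchanged the whole group on the carbonyl carbon, whereas compound 4 alters a single substituent on the aromatic ring. Among the measured compounds shown here, no measured pair varies a substituent on that ring, so the data give no firm direction. A smaller step than the one from ethyl to 4-methoxyphenyl is therefore expected, most likely inside the scatter. The estimated change is a 1.2-fold lower number from compound 3 to compound 4 (0.08 log units; within the scatter) and carries little weight as a direction. For compound 4 the expected value is 2500 nM with an estimated range from 1200 nM to 5000 nM on this read-out.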

Compound 4, half-maximal inhibitory concentration: 2550 nM
Compound 4: the middle estimate sits 1.0-fold (0.01 log units) below what was measured, and the stated range covers the measured number.
By their numbers in this assay, from the lowest: compounds 2, 4 and 3 (each within the scatter of the next, the first and the last beyond it); then compound 1.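

Chloro in place of methoxy on the aromatic carbon para to a large group gives (a 1.2-fold lower number from compound 3 to compound 4 (0.07 log units; within the scatter)) in this assay, so the first change of a substituent on this ring leaves the number within the scatter. With chloro at that place, the 4-chlorophenyl group on the carbonyl carbon also stays within the scatter of ethyl (a 1.8-fold higher number from compound 2 to compound 4 (0.26 log units; within the scatter)), while the step with 4-methoxyphenyl in that same exchange (a 2.1-fold higher number from compound 2 to compound 3 (0.33 log units; beyond the scatter)) is printed as just beyond it, so the two aromatic groups differ little from each other yet do not read alike against ethyl. The information at hand gives no explanation for any of these steps.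

Open, going by these compounds, is whether a substituent of a different kind at the same ring carbon, such as an amine or a carboxylic acid, would stay within the scatter of chloro and methoxy in this assay. Also open, on these data alone, is how a longer chain in place of ethyl on the carbonyl carbon, or an unsubstituted phenyl group there, would stand against compound 2 and compound 4.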